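The source may report more compounds than this note shows. Statements on the series, on what has been measured and on what is new or still open speak of the compounds shown alone.

Measured compounds:
- compound 1, `CCCN(CCC)c1ccc(Nc2ncc(Cl)c(Oc3cccc(NC(=O)CC)c3)n2)cc1`: in an assay on isolated protein for inhibition of NUAK family SNF1-like kinase 1 (Homo sapiens), read by ADP-Glo, with a stated time of 60 min, tested at 10 uM, in the presence of a further agent that is not named here (a higher number here means more inhibition at the concentration tested (going by the name of the read-out), a lower number less inhibition), compound 1 gives 9.3%
- compound 2, `CCC(=O)Nc1cccc(Oc2nc(Nc3ccc(N(C)C)cc3OC)ncc2Cl)c1`: in this assay compound 2 gives 80.6%
- compound 3, `CCC(=O)Nc1cccc(Oc2nc(Nc3ccc(N4CCC(C)CC4)cc3OC)ncc2Cl)c1`: in this assay compound 3 gives 9.2%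

Compound 1 therefore stands together with compound 3 at the low end of the three numbers, the two being within the scatter of each other, and far below compound 2. Among the measured compounds shown here, the one measured step, a number 71.4 percentage points lower from compound 2 to compound 3 (beyond the scatter), shows that enlarging the amine on the aromatic carbon from dimethylamino to 4-methylpiperidin-1-yl removes most of the inhibition.

Compound 4 is `CCC(=O)Nc1cccc(Oc2nc(Nc3ccc(N(CC)CC)cc3)ncc2Cl)c1`. It differs from compound 1 by diethylamino in place of dipropylamino on an aromatic carbon. This is a move toward a smaller amine, the opposite direction to the step from compound 2 to compound 3, so some recovery of inhibition is expected. For the measured compounds named here, compound 1, however, also lacks the methoxy of compound 2, and no measured step isolates that group, so the size of the expected rise is uncertain. The expected step is a number 22.7 percentage points higher from compound 1 to compound 4 (beyond the scatter). Compound 4 is therefore estimated at 32%, within a range from 8% to 65%.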

Compound 4, a percentage reported as inhibition, at one concentration (the size of the read-out at that concentration, not a potency): 54.4%
Compound 4: the middle estimate sits 22.4 percentage points below what was measured; the measured number falls inside the stated range.
By their numbers in this assay, from the lowest: compounds 3 and 1 (each within the scatter of the next); then compound 4; then compound 2.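

Diethylamino in place of dipropylamino gives a number 45.1 percentage points higher from compound 1 to compound 4 (beyond the scatter) in this assay and so shows that this position is sensitive to the amine even in a compound without the methoxy group. The earlier step went from dimethylamino to a ring-bearing amine, whereas this one stays with open-chain amines and moves only from 7 heavy atoms to 5, which is enough for a large change in inhibition. Nothing available gives a reason for this step.

As far as these compounds go, how much the methoxy group contributes remains open, as compound 4 and compound 2 differ in more than one place. Also open, from the compounds shown here alone, is how a cyclic amine such as pyrrolidin-1-yl or morpholin-4-yl, or an unbranched primary amine, would behave at this position.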